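A few compounds are considered here, and "the series" means these few. Any claim that something is new, unique, unknown or untested is made for them only; others in the source may bear on it.

Compound 1, `Cc1ccc(Nc2cncc(N3CC4CC(C3)N4)c2)cc1`, compound 2, `O=[N+]([O-])c1ccc(Nc2ccc(N3CC4CC(C3)N4)cn2)cc1`, and compound 3, `Fc1ccc(Nc2cncc(N3CC4CC(C3)N4)c2)cc1`, were all tested in an assay on HEK293 cells for displacement of a labelled ligand from Neuronal acetylcholine receptor; alpha3/beta4 (Homo sapiens); a higher number here means a weaker inhibitor, a lower number a stronger inhibitor. For the measured compounds named here, compound 1 gives 1.4 nM and compound 3 gives 1.25 nM; the one change between them, a 1.1-fold lower number from compound 1 to compound 3 (0.05 log units; within the scatter), does not move the number beyond the usual scatter. Compound 2 stands apart with 25 nM, the highest of the three numbers and well beyond the scatter from both compound 1 and compound 3. Compound 2 also carries the shared core in a different arrangement from compound 1 and compound 3, so it is not one step away from either of them.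

Compound 4, `Fc1ccc(Nc2ccc(N3CC4CC(C3)N4)cn2)cc1`, is built from compound 2 by a single change: fluoro in place of nitro on an aromatic carbon. Going by the values given here, no measured step tells directly how a fluoro replacing a nitro behaves here. Among the compounds with values here, the only measured step, from compound 1 to compound 3, concerns a fluoro in place of a methyl on a different core and lies within the scatter, so it offers only weak guidance. What can be said is that compound 3, which carries a fluoro at the corresponding spot on its own core, gives 1.25 nM, far below the value of compound 2. On that basis compound 4 is expected to come out somewhat lower than compound 2, a step of a 2.5-fold lower number from compound 2 to compound 4 (0.40 log units; beyond the scatter), with compound 4 estimated at 10 nM within a range of 2.5 nM to 40 nM in this assay.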

Compound 4, inhibition constant: 13 nM
Beside the measured number, compound 4's estimate is 1.3-fold (0.11 log units) below it, and the stated range covers the measured number.
By their numbers in this assay, from the lowest: compounds 3 and 1 (each within the scatter of the next); then compounds 4 and 2 (each within the scatter of the next).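

For the compounds shown here, replacing nitro with fluoro on an aromatic carbon para to a large group gives a 1.9-fold lower number from compound 2 to compound 4 (0.28 log units; within the scatter) in this assay, the first measured look at this change at this place. A group of three heavy atoms with two hydrogen-bond acceptors gives way to a single fluorine with none, yet the number stays within the usual scatter of repeated measurements, so the high number of compound 2 cannot be pinned on its nitro group. The earlier step of a 1.1-fold lower number from compound 1 to compound 3 (0.05 log units; within the scatter) also stayed within the scatter, but it started from methyl on a different core, so only now is there a change of this size in the group, and on this core, and among the compounds shown neither step moves the number beyond the scatter.

Whether this place would stay as undemanding with a different kind of group, such as an amine, a carboxylic acid or a longer chain, remains open from the compounds shown. No measurement available here offers an explanation for why the number holds across this swap.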